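Carbamate series: sulfonamide replacing the amide on the aryl ring

This account rests on a few compounds, and the source may have more. Where it says the series, first, only, none or still open, it means among the compounds named here.

Of the compounds shown here, two of the shared core have a number so far. Compound 1 `COc1ccc(OC(=O)N2CCC(C(O)(c3ccccc3)c3ccccc3)CC2)cc1` gives 2680 nM in a functional assay for antagonist activity at Neuropeptide Y receptor type 2 (Homo sapiens); a higher number here means a weaker inhibitor, a lower number a stronger inhibitor. Compound 2 `CCN(CC)C(=O)c1ccc(OC(=O)N2CCC(C(O)(c3ccccc3)c3ccccc3)CC2)cc1` gives 220 nM in this assay, which is the lowest of the two numbers; the step of a 12-fold lower number from compound 1 to compound 2 (1.09 log units; beyond the scatter) separates them, and it lies beyond the scatter.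

Compound 3 `CS(=O)(=O)Nc1ccc(OC(=O)N2CCC(C(O)(c3ccccc3)c3ccccc3)CC2)cc1` is not yet measured. It differs from compound 2 in one place: methanesulfonamido in place of diethylcarbamoyl on an aromatic carbon. For the measured compounds named here, the only measured step on this ring position is a 12-fold lower number from compound 1 to compound 2 (1.09 log units; beyond the scatter), and it concerns the exchange of methoxy for diethylcarbamoyl, not the exchange made here. Going by the values given here, the methanesulfonamido group matches neither of the two groups already seen, so the measured step gives only the span within which the substituent at this position has moved the number so far.

Among the compounds with values here, compound 3 is therefore expected to fall between the two known numbers, nearer the weaker end, with an estimated step of a 3.2-fold higher number from compound 2 to compound 3 (0.50 log units; beyond the scatter) in this assay. The estimate for compound 3 is 700 nM, with a range from 200 nM to 2500 nM.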

Compound 3, half-maximal inhibitory concentration: 394 nM
Compound 3: the middle estimate sits 1.8-fold (0.25 log units) above what was measured, and the stated range covers the measured number.
By their numbers in this assay, from the lowest: compounds 2 and 3 (each within the scatter of the next); then compound 1.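

In this assay the exchange of the diethylcarbamoyl group for the methanesulfonamido group gives a 1.8-fold higher number from compound 2 to compound 3 (0.25 log units; within the scatter) so this position accepts two quite different groups without a separable change in the number, although only the methanesulfonamido group carries a hydrogen-bond donor. Set against the methoxy group, the methanesulfonamido group gives a 6.8-fold lower number from compound 1 to compound 3 (0.83 log units; beyond the scatter) which shows that the earlier drop from the methoxy compound is not unique to the diethylcarbamoyl group and can be reached with a sulfonyl-containing group of fewer heavy atoms. No supporting evidence is available to explain why these two groups read alike at this position.

The compounds shown leave open how an amine, a carboxylic acid or a primary carboxamide would read on this aromatic carbon, and whether a longer chain in place of the methyl on the sulfonyl group would keep the number of compound 3 or move it. They also leave open whether the match between compound 2 and compound 3 would persist with other changes to the shared core.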